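Moving a trifluoromethyl group on the phenyl ether

The source may report more compounds than this note shows. Statements on the series, on what has been measured and on what is new or still open speak of the compounds shown alone.

In an ADME assay on PBMC cells (Homo sapiens) for cytotoxicity (a lower number here means that less compound is tolerated, a higher number that more compound is tolerated), compound 1 `CC(CCNC(=O)c1c(Cl)cncc1Cl)N1CCC(C(Oc2cccc(C#N)n2)c2ccc(C(F)(F)F)cc2)CC1` gives 15700 nM and compound 2 `COc1cccc(OC(c2ccc(C(F)(F)F)cc2)C2CCN(C(C)CCNC(=O)c3c(Cl)cncc3Cl)CC2)n1` gives 32700 nM while compound 3 `CC(CCNC(=O)c1c(Cl)cncc1Cl)N1CCC(C(Oc2ccc(C(F)(F)F)cc2)c2ccc(C(F)(F)F)cc2)CC1` gives 3100 nM as the lowest of the three numbers. Putting 4-(trifluoromethyl)phenyl in place of the pyridine-based groups produced the two widest gaps, with a 5.1-fold lower number from compound 1 to compound 3 (0.70 log units; beyond the scatter) as the modest one and an 11-fold lower number from compound 2 to compound 3 (1.02 log units; beyond the scatter) as the large one.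

Compound 4 `CC(CCNC(=O)c1c(Cl)cncc1Cl)N1CCC(C(Oc2cccc(C(F)(F)F)c2)c2ccc(C(F)(F)F)cc2)CC1` carries 3-(trifluoromethyl)phenyl in place of 4-(trifluoromethyl)phenyl on an oxygen on a saturated carbon and so differs from compound 3 only in how the same atoms are joined. For the measured compounds named here, no measured step moves a group around an unchanged ring, so the data bear on this change only indirectly. Both large exchanges replaced one whole aromatic group with another, which compound 4 does not do. The nearest comparison is the substituent swap alone, a 2.1-fold higher number from compound 1 to compound 2 (0.32 log units; beyond the scatter) and only just beyond the scatter. On that basis, no step beyond the scatter is expected, and the expected step is a 1.3-fold higher number from compound 3 to compound 4 (0.11 log units; within the scatter) in a slightly higher direction. Compound 4 is estimated at 4000 nM with an expected range from 1800 nM to 9000 nM as its likely span.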

Compound 4, half-maximal cytotoxic concentration: 7000 nM
Beside the measured number, compound 4's estimate is 1.8-fold (0.24 log units) below it, within the range that was stated.
By their numbers in this assay, from the lowest: compound 3; then compound 4; then compound 1; then compound 2.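

In this assay, moving the trifluoromethyl group around an otherwise unchanged phenyl ring is enough on its own to shift the number, with a 2.3-fold higher number from compound 3 to compound 4 (0.35 log units; beyond the scatter) showing that the place of this group on the phenyl ether matters and not only the exchange of one whole aromatic group for another. Even so, 3-(trifluoromethyl)phenyl does not close the gap to the pyridine-based groups, since a 4.7-fold lower number from compound 2 to compound 4 (0.67 log units; beyond the scatter) and a 2.2-fold lower number from compound 1 to compound 4 (0.35 log units; beyond the scatter) leave compound 4 in the same direction from both as compound 3, although both of these steps are modest. No measurement is available here that explains why the two trifluoromethyl placements differ.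

The compounds shown do not tell whether the same shift would appear with another group on the phenyl ring, such as a carboxylic acid or an amine in place of trifluoromethyl. They also leave open whether a phenyl ring with two trifluoromethyl groups would give a number nearer to that of compound 3 or to that of compound 4.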